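Furan-2-yl to furan-3-yl on two dihydropyrimidine cores

The source may report more compounds than this note shows. Statements on the series, on what has been measured and on what is new or still open speak of the compounds shown alone.

Measured compounds in an assay on membranes from CHO cells for displacement of a labelled ligand from adenosine receptor A1 (Homo sapiens), read by scintillation counting, with a stated time of 60 min, tested at 1 uM; a higher number here means more inhibition at the concentration tested (going by the name of the read-out), a lower number less inhibition:
compound 1, `CC1=C(C(=O)OC(C)(C)C)C(c2ccco2)NC(=S)N1`, 3%
compound 2, `CC1=C(C(=O)OC(C)(C)C)C(c2ccoc2)NC(=S)N1`, 18%
compound 3, `COC(=O)C1=C(C)N(C)C(=O)NC1c1ccco1`, 45%

Compound 1 and compound 2 differ by furan-3-yl in place of furan-2-yl on a saturated ring carbon, and this change gave a number 15 percentage points higher from compound 1 to compound 2 (beyond the scatter). Compound 3 stands highest of the three in this assay. How the core of compound 3 differs from that of compound 1 is not broken down here. Compound 4, `COC(=O)C1=C(C)N(C)C(=O)NC1c1ccoc1`, is not yet measured; it differs from compound 3 by furan-3-yl in place of furan-2-yl on a saturated ring carbon. The surroundings of the place are not identical, since in compound 1 the neighbouring ring atom bears a group of 7 heavy atoms while in compound 3 it bears a methoxycarbonyl group, so this is the same kind of change rather than the same change. The step from compound 3 to compound 4 is expected to be a number 13 percentage points higher from compound 3 to compound 4 (beyond the scatter), resting on the earlier step from compound 1 to compound 2. For compound 4 the estimated value is 58%, expected to lie between 40% and 75%.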

Compound 4, a percentage reported as inhibition, at one concentration (the size of the read-out at that concentration, not a potency): 15%
Compound 4: middle estimate off by 43 percentage points, on the high side; measured number outside the range, below it.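

In this assay, furan-3-yl in place of furan-2-yl on a saturated ring carbon gave a number 30 percentage points lower from compound 3 to compound 4 (beyond the scatter). Among the compounds shown here, the same change therefore does not carry over from one core to the other, and its direction reverses in this pair of cores: the same change on two cores in this assay, a number 15 percentage points higher (beyond the scatter) from compound 1 to compound 2 and a number 30 percentage points lower (beyond the scatter) from compound 3 to compound 4, 45 percentage points apart, beyond the scatter of two such steps This shows that the step depends on the core, but with only two pairs and cores that differ in more than one place, it does not show which core difference is responsible.

Still open, from the compounds shown here alone, is how a phenyl or thiophene ring would read on that saturated ring carbon. Also open, going by these compounds, is whether an ethoxycarbonyl group in place of the methoxycarbonyl group would keep the direction seen on the core of compound 3.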